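This account rests on a few compounds, and the source may have more. Where it says the series, first, only, none or still open, it means among the compounds named here.

In a functional assay on HT-29 cells (Homo sapiens) for cytotoxicity, read by MTT assay, with a stated time of 48 h (a lower number here means a stronger inhibitor, a higher number a weaker inhibitor), compound 1 `COCCCN1C(/C=C/c2ccc(O)cc2)=CC(=O)CC1c1ccc(O)cc1` gives only a limit of > 100000 nM. Compound 2 `COc1cc(/C=C/C(=O)/C=C(/C=C/c2ccc(O)c(OC)c2)NCCCO)ccc1O` likewise reaches only a limit of > 100000 nM in this assay. For compound 2 the value sits at the limit of > 100000 nM in this assay, at which 2 of the 2 values shown sit, so no number is known for it. Compound 3 `COCCCNC(=C\C(=O)/C=C/c1ccc(O)c(OC)c1)/C=C/c1ccc(O)c(OC)c1` differs from compound 2 by methyl in place of hydrogen on an oxygen on a saturated carbon. No step between measured compounds is known here, so the change carries no shown effect. Compound 3 is expected to show no step beyond the scatter, with a step that the limit leaves unreadable from compound 2 to compound 3. Compound 3 is thus estimated at 150000 nM, between 50000 nM and 500000 nM, most likely again only a limit.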

Compound 3, half-maximal inhibitory concentration: 72200 nM
The estimate for compound 3 lay 2.1-fold (0.32 log units) above the measured number; the range from low to high includes it.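

With methyl in place of hydrogen on an oxygen on a saturated carbon, compound 3 has a real number in this assay, where compound 2 has none. This gives an at least 1.3-fold lower number from compound 2 to compound 3 (0.14 log units; that floor lies within the scatter), and only a floor can be stated for the step, so this position is not shown to matter beyond the scatter. The value of compound 2 remains a limit: the limit of > 100000 nM in this assay, at which 2 of the 3 values shown sit.

Going by these compounds, the true size of the step stays open. So does whether an amine, a carboxylic acid or a longer chain at this position would move the number.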